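The compounds below may be only part of what the source reports. "The series", "measured", "known", "first", "only" and "open" are said of these compounds alone.

Of the compounds shown here, three built on the same core have been tested in a functional assay on KETR3 cells (Homo sapiens) for inhibition, read by MTT assay, with a stated time of 120 h; a lower number here means a stronger inhibitor, a higher number a weaker inhibitor. Compound 1 `CNC(=O)C#Cc1ccc(NC(=O)Nc2ccc(Cl)c(C(F)(F)F)c2)cc1` gives 24700 nM. Compound 2 `O=C(/C=C/c1ccc(NC(=O)Nc2ccc(Cl)c(C(F)(F)F)c2)cc1)NC1CCC1` gives 17300 nM. Compound 3 `CNC(=O)/C=C/c1ccc(NC(=O)Nc2ccc(Cl)c(C(F)(F)F)c2)cc1` gives 21200 nM. Among these three numbers compound 3 stands second highest, and all three lie close together: the steps of a 1.2-fold lower number from compound 1 to compound 3 (0.07 log units; within the scatter), a 1.4-fold lower number from compound 1 to compound 2 (0.15 log units; within the scatter) and a 1.2-fold higher number from compound 2 to compound 3 (0.09 log units; within the scatter) are each within the scatter, so none of the three compounds can be called stronger or weaker than another on this evidence.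

Compound 4 `CC1CN(C(=O)/C=C/c2ccc(NC(=O)Nc3ccc(Cl)c(C(F)(F)F)c3)cc2)CC(C)O1` has not yet been measured in this assay. It differs from compound 3 at the amide end of the chain: 2,6-dimethylmorpholin-4-yl in place of methylamino on a carbonyl carbon. The entering group brings a ring and takes away the hydrogen-bond donor that the methylamino group carried.

For the measured compounds named here, the one measured step that touches the same part of the molecule is a 1.2-fold higher number from compound 2 to compound 3 (0.09 log units; within the scatter), where swapping the group on the amide-type nitrogen left the number within the scatter. No measured step removes the hydrogen-bond donor, so that part of the change has no precedent among these compounds. On this basis the expected step is a 1.1-fold lower number from compound 3 to compound 4 (0.03 log units; within the scatter), that is, no movement beyond the scatter. Compound 4 is therefore estimated at 20000 nM, with a range from 7000 nM to 55000 nM.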

Compound 4, half-maximal inhibitory concentration: > 50000 nM
Compound 4: no number, only a limit (the forecaster's own chance of this, stated with the estimate: 10%); middle value at least 2.5-fold (0.39 log units) from the limit.
By their numbers in this assay, from the lowest: compounds 2, 3 and 1 (each within the scatter of the next). At a limit, above all of these: compound 4.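

Compounds 2 and 3 had suggested that the amide end of the chain could change without consequence, since methyl and cyclobutyl on the amide-type nitrogen stayed within the scatter of each other, but in this assay this position now proves sensitive to what is attached there, with an at least 2.3-fold higher number from compound 3 to compound 4 (0.37 log units; beyond the scatter) and an at least 2.8-fold higher number from compound 2 to compound 4 (0.46 log units; beyond the scatter). For the compounds shown here, these are the first steps at this position that go beyond the scatter, and they show that replacing a secondary amide with the 2,6-dimethylmorpholin-4-yl amide does not leave the number unchanged. Compound 4 has no exact number, so both steps give only a minimum size and the true loss could be larger, as this value is a limit of the assay: the limit of > 50000 nM in this assay, at which 1 of the 4 values shown sits.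

Compound 4 loses the amide hydrogen and gains a ring with two methyl groups in a single change, and the compounds shown cannot tell these parts apart. A dimethylamino group, with no amide hydrogen and no ring, or a morpholin-4-yl group without the two methyl groups, would help separate them.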